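The source may hold more compounds than are shown below. What is called first, only, known or untested is meant among the compounds shown, and "the series" means these compounds.

Three compounds share one core and differ in the group on the amide-type nitrogen and in the five-membered ring. Compound 1 `O=C(NC1CCCC1)Oc1ccc(C2=NCCS2)cc1` gives 130 nM in an assay on cell membranes (strain Wistar) for inhibition of Fatty-acid amide hydrolase 1 (Rattus norvegicus), read by scintillation counting; a lower number here means a stronger inhibitor, a higher number a weaker inhibitor. Compound 2 `Cc1ccccc1CNC(=O)Oc1ccc(C2=NCCS2)cc1` gives 62 nM in this assay. Compound 3 `CCCCNC(=O)Oc1ccc(C2=NCCO2)cc1` gives 120 nM in this assay. On these three numbers compound 3 stands second highest, yet its gaps to compound 1 and to compound 2 both fall within the usual scatter, so no ranking can be drawn. Compound 4 `O=C(NC1CCCC1)Oc1ccc(C2=NCCO2)cc1` differs from compound 3 by one change: cyclopentyl in place of butyl on an amide-type nitrogen. Among the compounds with values here, no measured pair shows this step alone. The expected step of a 1.1-fold higher number from compound 3 to compound 4 (0.03 log units; within the scatter) is none beyond the scatter. Compound 4 is estimated at 130 nM in this assay, with a range from 60 nM to 280 nM.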

Compound 4, half-maximal inhibitory concentration: 100 nM
For compound 4 the middle estimate is 1.3-fold (0.11 log units) above the measured one, and the stated range covers the measured number.
By their numbers in this assay, from the lowest: compounds 2, 4, 3 and 1 (each within the scatter of the next, the first and the last beyond it).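

In this assay, cyclopentyl in place of butyl on an amide-type nitrogen gives a 1.2-fold lower number from compound 3 to compound 4 (0.08 log units; within the scatter), so this first one-place comparison does not tell the ring from the open chain at this position. Replacing the sulfur-containing five-membered ring of compound 1 with the oxygen-containing one gives a 1.3-fold lower number from compound 1 to compound 4 (0.11 log units; within the scatter), so these two rings cannot be told apart here either. Nothing available explains these results. Still open, going by these compounds, is whether a much longer chain, such as octyl, or a carboxylic acid on the end of the butyl chain would shift the number beyond the scatter.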